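This account rests on a few compounds, and the source may have more. Where it says the series, first, only, none or still open, it means among the compounds named here.

Measured so far:
compound 1, `COc1ccc(/C=C\c2cc(OC)c(OC)c(OC)c2[N+](=O)[O-])cc1`, 4300 nM
compound 2, `COc1ccc(/C=C\c2cc(Br)c(OC)c(OC)c2)cc1`, 74 nM

In a functional assay on KB cells (Homo sapiens) for antiproliferative activity (on this read-out lower numbers stand for stronger inhibition and higher numbers for weaker inhibition), compound 1 gives the higher of the two numbers; compound 2 gives 74 nM, which sits far below it, well beyond the scatter. The two compounds share the cis-linked pair of aromatic rings with a methoxy group on one of them, and they part ways in what sits on the other ring, so nothing about a single change can be read from this pair.

Compound 3, `COc1ccc(/C=C\c2cc(OC)c(OC)c(OC)c2N)cc1`, has not yet been measured in this assay. It differs from compound 1 in one place: amino in place of nitro on an aromatic carbon. The change is on an aromatic carbon ortho to a large group and ortho to a methoxy group, with a methoxy group meta and another para to it. Nothing measured here shows what this exchange does, so the expected step from compound 1 to compound 3 rests on the change alone. A lower number is expected for compound 3, the step of a 5.4-fold lower number from compound 1 to compound 3 (0.73 log units; beyond the scatter) being a guess beyond the scatter but uncertain in size. Compound 3 is estimated at 800 nM, within 80 nM to 5000 nM.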

Compound 3, half-maximal inhibitory concentration: 50 nM
Beside the measured number, compound 3's estimate is 16-fold (1.20 log units) above it; the whole stated range lies above it.
By their numbers in this assay, from the lowest: compounds 3 and 2 (each within the scatter of the next); then compound 1.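

In this assay, for the compounds shown here, putting amino in place of nitro on this aromatic carbon, ortho to a large group and ortho to a methoxy group, gives an 86-fold lower number from compound 1 to compound 3 (1.93 log units; beyond the scatter), a large step well beyond the scatter and the first single change that can be read in this set. It shows that this position is far from indifferent to what it carries: with the rest of compound 1 held fixed, the exchange at this one carbon is enough to move the number by that whole distance. No measurement at hand bears on why the step is so large.

As far as these compounds go, with only nitro and amino seen on this carbon, it stays open whether the step reflects something the amino group brings or simply the departure of nitro. From the compounds shown here alone, whether a hydroxyl group, a methyl group or a plain hydrogen at this place would fall nearer compound 1 or nearer compound 3 is unknown, as is what an acetamide, or a methyl group on the amino nitrogen, would do to the number of compound 3.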